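The source may hold more compounds than are shown below. What is called first, only, known or untested is meant among the compounds shown, and "the series" means these compounds.

In a physicochemical assay for metabolic stability, read by HPLC, in phosphate buffer, at pH 7.4, tested at 10 uM (a higher number here means that the compound lasts longer, a lower number that the compound disappears faster), compound 2 `O=C(c1ccccc1)c1ccc2c(c1)oc(=O)n2C(=O)NCCCCc1ccccc1` gives 1.63 h. Compound 1 `O=C(NCCCCc1ccccc1)n1c(=O)oc2cc(Cl)c(Cl)cc21` gives 0.917 h in this assay, and the gap between compound 1 and compound 2 lies within the usual scatter of this kind of measurement, so the two numbers cannot be told apart. Compound 3 `O=C(NCCCCc1ccccc1)n1c(=O)oc2cc(-c3ccc(F)cc3)ccc21` differs from compound 2 in one place: 4-fluorophenyl in place of benzoyl on an aromatic carbon. For the measured compounds named here, no measured step bears on this change. The expected step is a 1.2-fold lower number from compound 2 to compound 3 (0.07 log units; within the scatter), an estimate that stays within the scatter and carries no firm direction. Compound 3 is expected to give 1.4 h in this assay, in a range from 0.6 h to 3.2 h.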

Compound 3, half-life: > 5 h
Compound 3: no number, only a limit (the forecaster's own chance of this, stated with the estimate: 5%); middle value at least 3.5-fold (0.55 log units) from the limit.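

In this assay, 4-fluorophenyl in place of benzoyl on an aromatic carbon gives an at least 3.0-fold higher number from compound 2 to compound 3 (0.48 log units; beyond the scatter). For the compounds shown here, this shows that a change at this carbon alone can move the half-life beyond the scatter, which the earlier compounds did not show. Compound 3 carries a limit of the assay and not a number, so the step is a lower bound: the limit of > 5 h in this assay, at which 1 of the 3 values shown sits.

As far as these compounds go, how far the true value of compound 3 lies past that limit remains open. Also open, from the compounds shown here alone, is whether plain phenyl, an amine or a carboxylic acid on this carbon would give a similar result.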